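The source may hold more compounds than are shown below. What is called first, only, known or untested is meant among the compounds shown, and "the series" means these compounds.

In a functional assay on HT cells (Homo sapiens) for antiproliferative activity, read by fluorescence, with a stated time of 72 h (on this read-out lower numbers stand for stronger inhibition of growth and higher numbers for weaker inhibition of growth), two compounds with the same core have been measured so far. Compound 1 `CC(C)c1n[nH]c2c(NCc3ccc(-c4ccccn4)cc3)nc(SCCO)nc12`, which carries 2-hydroxyethyl on a sulfur, gives 48 nM. Compound 2 `CC(C)c1n[nH]c2c(NCc3ccc(-c4ccccn4)cc3)nc(SC3CCCC3O)nc12`, which carries 2-hydroxycyclopentyl on that sulfur, gives 567 nM, the higher of the two numbers and so the weaker inhibition of growth. Within the data shown here, compound 3 `CC(C)c1n[nH]c2c(NCc3ccc(-c4ccccn4)cc3)nc(SCCNC(N)=O)nc12` keeps the core and changes only this group: 2-ureidoethyl in place of 2-hydroxycyclopentyl on a sulfur.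

Among the measured compounds shown here, one measured step bears on this change, and it is large: a 12-fold higher number from compound 1 to compound 2 (1.07 log units; beyond the scatter). In that step an open chain gave way to a ring. Compound 3 gives up the ring again and has an ethyl chain, like compound 1 at 48 nM, so its number is expected to fall back towards that value. For the measured compounds named here, the ureido end has no measured counterpart, however, so a full return cannot be assumed, and the range must stay wide. The expected change is a 5.2-fold lower number from compound 2 to compound 3 (0.71 log units; beyond the scatter), a move towards stronger inhibition. The estimate for compound 3 is 110 nM, with an expected range from 35 nM to 350 nM.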

Compound 3, concentration for 50% growth inhibition: 240 nM
Compound 3: the middle estimate sits 2.2-fold (0.34 log units) below what was measured; measured number inside the range.
By their numbers in this assay, from the lowest: compound 1; then compound 3; then compound 2.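

In this assay, replacing the 2-hydroxycyclopentyl group on the sulfur with the open 2-ureidoethyl chain gives a 2.4-fold lower number from compound 2 to compound 3 (0.37 log units; beyond the scatter), so this change moves the number down, though not all the way to that of compound 1. Having an open chain on the sulfur is therefore not enough on its own: with the chain kept and ureido in place of hydroxy, the result is a 5.0-fold higher number from compound 1 to compound 3 (0.70 log units; beyond the scatter). The group at the end of the chain thus matters at this position as well as the choice between ring and chain, but no available measurement explains either difference.

These compounds leave open how other ends on the same ethyl chain, such as an amine, a carboxylic acid or a methoxy group, would compare with hydroxy and ureido. From the compounds shown here alone, it also remains unknown whether a longer chain ending in hydroxy would stay close to compound 1, and whether a plain cyclopentyl ring without its hydroxy would stay close to compound 2.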